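The compounds below may be only part of what the source reports. "The series", "measured", "known", "first", "only" and "open" are said of these compounds alone.

Compound 1, `Cc1cc(Nc2nn(Cc3ccc(S(C)(=O)=O)cc3)c(=O)c3ccccc23)n[nH]1`, gives 4500 nM in a functional assay on MCF7 cells (Homo sapiens) for cytotoxicity; a lower number here means a stronger inhibitor, a higher number a weaker inhibitor.
Compound 2, `CC(=O)Nc1ccc(Cn2nc(Nc3cc[nH]n3)c3ccccc3c2=O)cc1`, gives > 30000 nM in this assay.

Of the compounds shown here, two have been tested for how strongly they hold back the growth of a breast cancer cell line. Compound 1 is the only one that returned a real number, 4500 nM in this assay, so there is nothing to rank it against. For compound 2 the result is only a limit of the assay, > 30000 nM, and its true value is not known. One of the two values shown thus sits at the limit of > 30000 nM in this assay, at which 1 of the 2 values shown sits.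

Compound 3, `Cc1cc(Nc2nn(Cc3ccc([N+](=O)[O-])cc3)c(=O)c3ccccc23)n[nH]1`, has not yet been measured. It differs from compound 1 in one place: nitro in place of methylsulfonyl on an aromatic carbon. Within the data shown here, no measured pair of compounds shows what such an exchange does here, so the step of a 1.1-fold higher number from compound 1 to compound 3 (0.05 log units; within the scatter) is expected to stay within the usual scatter, in no particular direction. Compound 3 is therefore expected to give about 5000 nM, most likely between 1500 nM and 20000 nM.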

Compound 3, half-maximal inhibitory concentration: > 30000 nM
Compound 3: no number, only a limit; the forecaster's own chance of this, stated with the estimate: 20%; middle value at least 6.0-fold (0.77 log units) from the limit.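

Among these compounds, this is the only readable change at this aromatic carbon, and it shows that the group there matters in this assay: putting nitro in place of methylsulfonyl, two groups with the same count of hydrogen-bond acceptors and no net charge, gives an at least 6.6-fold higher number from compound 1 to compound 3 (0.82 log units; beyond the scatter). For compound 3, the result of > 30000 nM is a limit of the assay and not a number. From the compounds shown here alone, the true size of the step therefore remains unknown and could be larger, because the read-out stops at a limit: the limit of > 30000 nM in this assay, at which 2 of the 3 values shown sit.

Among the compounds shown here, with only two groups compared at this carbon, it remains open whether nitro is especially poor here or methylsulfonyl is especially favourable. An amine or a carboxylic acid at the same carbon, in the setting of compound 1, would help to tell these two readings apart.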